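A few compounds are considered here, and "the series" means these few. Any claim that something is new, unique, unknown or untested is made for them only; others in the source may bear on it.

Compound 1 `O=S(=O)(/C=C/c1ccc(O)c(O)c1)Cc1ccccc1`, compound 2 `O=S(=O)(/C=C/c1ccc(O)c(O)c1)CCc1ccccc1` and compound 3 `[O-][S+](/C=C/c1ccc(O)c(O)c1)CCc1ccccc1` have been run through a physicochemical assay for permeability, using PAMPA, with a stated time of 18 h, tested at 5 mg/mL; a higher number here means that the compound crosses the layer faster, a lower number that the compound crosses the layer more slowly. In this assay compound 1 gives 10.1 10^-6 cm/s. Compound 2 gives 5.7 10^-6 cm/s. Compound 3 gives 5 10^-6 cm/s. Among the compounds with values here, the one measured pair that differs in a single place is compound 1 and compound 2: the change is benzyl in place of phenyl on a saturated chain carbon bound to a sulfonyl sulfur and it brought a 1.8-fold lower number from compound 1 to compound 2 (0.25 log units; within the scatter). Compound 3 and compound 1 differ in their cores, and that difference is not broken down here; the two values can only be set side by side, and compound 3 sits a little lower than compound 1.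

Compound 4 `[O-][S+](/C=C/c1ccc(O)c(O)c1)CCCc1ccccc1` has not yet been measured. It relates to compound 3 as compound 2 relates to compound 1: the change is benzyl in place of phenyl on a saturated chain carbon, two bonds along the chain from a sulfur. Within the data shown here, it is the same kind of change as the one from compound 1 to compound 2, but not the same, since in compound 1 the group sits on a saturated chain carbon bound to a sulfonyl sulfur, while in compound 3 it sits on a saturated chain carbon, two bonds along the chain from a sulfur.

The expectation for compound 4 therefore rests on one step alone, and it is expected to move by a 1.5-fold lower number from compound 3 to compound 4 (0.18 log units; within the scatter), resting on compound 1 to compound 2 having given a 1.8-fold lower number from compound 1 to compound 2 (0.25 log units; within the scatter). Compound 4 is thus estimated to reach 3.3 10^-6 cm/s, with a likely span from 1.8 10^-6 cm/s to 6.5 10^-6 cm/s.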

Compound 4, apparent permeability: 9.1 10^-6 cm/s
For compound 4 the middle estimate is 2.8-fold (0.44 log units) below the measured one; measured number above the stated range.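

In this assay, putting benzyl in place of phenyl gave a 1.8-fold higher number from compound 3 to compound 4 (0.26 log units; within the scatter) and, on the other core, gave a 1.8-fold lower number from compound 1 to compound 2 (0.25 log units; within the scatter) and these two steps are the only direct view of how this change carries from one core to another. Their numbers point in opposite directions, but each step is within the usual scatter of repeated measurements, so this does not show that the change reverses between the cores, and it does not show that the change truly raises or lowers the number on either core. Within the data shown here, what the new step does show is more modest: with only one earlier step to go on and both steps this small, neither the size nor the direction of that step can be relied on when moving to a new core, and no other measurement here bears on the result.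

As far as these compounds go, whether any replacement at this place could give a step beyond the scatter remains open, for instance a longer chain, an amine or a carboxylic acid in place of benzyl. Also open is how the same change from phenyl to benzyl would behave on further cores, since the compounds shown offer only these two pairs.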